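The source may hold more compounds than are shown below. What is called first, only, known or untested is meant among the compounds shown, and "the series" means these compounds.

Measured compounds:
compound 1, `COc1cccc(Cc2ccc3cc(NC(=O)c4ccc(O)c(CC=C(C)C)c4)c(=O)oc3c2C)c1`: 19700 nM
compound 2, `COc1ccc(Cc2ccc3cc(NC(=O)c4ccc(O)c(CC=C(C)C)c4)c(=O)oc3c2C)cc1OC`: 13900 nM
compound 3, `COc1cccc(-c2cc(C(=O)Nc3cc4ccc(Cc5ccccc5)c(C)c4oc3=O)ccc2OC)c1`: 7110 nM

All three were run in a functional assay on MCF7 cells (Homo sapiens) for antiproliferative activity; a lower number here means a stronger inhibitor, a higher number a weaker inhibitor. Compound 1 and compound 2 share one core; compound 3 carries a different core, and the difference between the two cores is not broken down here. Compound 3 gives the lowest of the three numbers, but its gap to compound 2 sits within the scatter, so no order between those two is claimed; only its gap to compound 1 lies beyond the scatter.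

Among the compounds with values here, the one counted step in this set is the change from compound 1 to compound 2, (methoxy in place of hydrogen on an aromatic carbon), which gave a 1.4-fold lower number from compound 1 to compound 2 (0.15 log units; within the scatter) in this assay.

Compound 4, `COc1ccc(Cc2ccc3cc(NC(=O)c4ccc(OC)c(-c5cccc(OC)c5)c4)c(=O)oc3c2C)cc1`, has not yet been measured. It differs from compound 3 by methoxy in place of hydrogen on an aromatic carbon. This is the same kind of change as that from compound 1 to compound 2, but not the same: in compound 2 the entering methoxy sits ortho to a methoxy group and para to a large group, whereas in compound 4 it sits para to a large group with no methoxy group noted around it.

Within the data shown here, on the strength of the single prior step a 1.4-fold lower number from compound 1 to compound 2 (0.15 log units; within the scatter), a step of similar size, within the scatter, is expected for compound 4, namely a 1.3-fold lower number from compound 3 to compound 4 (0.11 log units; within the scatter). Compound 4 is therefore estimated at 5500 nM in this assay, with a range from 2500 nM to 12000 nM.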

Compound 4, half-maximal inhibitory concentration: > 100000 nM
Compound 4: no number, only a limit (the forecaster's own chance of this, stated with the estimate: 3%); at least 18-fold (1.25 log units) between middle value and limit.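

On the core of compound 3, methoxy in place of hydrogen on an aromatic carbon, para to a large group, gave an at least 14-fold higher number from compound 3 to compound 4 (1.14 log units; beyond the scatter) in this assay, so this change cannot be carried from one core to the other in this series as a fixed step: the same change on two cores in this assay, a 1.4-fold lower number (0.15 log units; within the scatter) from compound 1 to compound 2 and an at least 14-fold higher number (1.14 log units; beyond the scatter) from compound 3 to compound 4, at least 19-fold (1.29 log units) apart, beyond the scatter of two such steps

Compound 4 stands at > 100000 nM, which is a limit of the assay and not a number, so the full size of its step stays unknown: the limit of > 100000 nM in this assay, at which 1 of the 4 values shown sits.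

Two pairs show that the outcome differs between these cores, but not what sets the two apart, since the cores differ in more than one feature and the surroundings of the entering methoxy differ as well, so neither can be singled out.

With only hydrogen and methoxy compared at this place, the compounds shown leave open how an ethoxy, an amine or a carboxylic acid there would read on the core of compound 3. They also leave open whether the same change on the core of compound 3 at another carbon of that ring gives a step of this kind.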